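Replacing methoxy with bromo in compound 1

This account rests on a few compounds, and the source may have more. Where it says the series, first, only, none or still open, it means among the compounds named here.

- compound 1 `CCCSc1nc(N/N=C(\C)c2ccc(OC)cc2)c2nnn(Cc3ccccc3)c2n1` gives 44300 nM
- compound 2 `C#CCSc1nc(N/N=C(\C)c2ccccc2O)c2nnn(Cc3ccccc3)c2n1` gives 3820 nM
- compound 3 `CCCSc1nc(N/N=C/c2ccc([N+](=O)[O-])cc2)c2nnn(Cc3ccccc3)c2n1` gives 10100 nM

These values come from a functional assay on MGC-803 cells (Homo sapiens) for antiproliferative activity, read by MTT assay, with a stated time of 72 h (a lower number here means a stronger inhibitor, a higher number a weaker inhibitor), and compound 1 has the highest of the three numbers, with both gaps beyond the scatter. Compound 4 `CCCSc1nc(N/N=C(\C)c2ccc(Br)cc2)c2nnn(Cc3ccccc3)c2n1` is still unmeasured. It carries bromo in place of methoxy on an aromatic carbon para to a large group bromo in place of methoxy on an aromatic carbon and so turns 4-methoxyphenyl into 4-bromophenyl. Within the data shown here, no single-change step links the measured compounds, so only their values can guide the expectation. The propyl chain of compound 1 is kept but other parts differ in compound 3, and compound 3 gives 10100 nM as the nearest number. A lower number is therefore expected for compound 4. The expected step of a 3.0-fold lower number from compound 1 to compound 4 (0.47 log units; beyond the scatter) is moderate in size. The estimate for compound 4 is 15000 nM with an expected range from 4000 nM to 45000 nM in this series.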

Compound 4, half-maximal inhibitory concentration: 6020 nM
Compound 4: the middle estimate sits 2.5-fold (0.40 log units) above what was measured; low and high end bracket the measured number.
By their numbers in this assay, from the lowest: compounds 2, 4 and 3 (each within the scatter of the next, the first and the last beyond it); then compound 1.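

In this assay, the series now has its first single-change step, a 7.4-fold lower number from compound 1 to compound 4 (0.87 log units; beyond the scatter), which is beyond the scatter. With the propyl chain and the shared core held constant, changing only the group on the aromatic carbon para to a large group shifts the antiproliferative number, so this position is not silent. No measurement here accounts for the step.

On these data alone, whether chloro, methyl or an amine at this position would give a similar number remains open. So does whether bromo gives a comparable step with a longer chain in place of propyl.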